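Sulfonamide-imidazole series: inhibition of cytochrome P450 11B1

The compounds below may be only part of what the source reports. "The series", "measured", "known", "first", "only" and "open" are said of these compounds alone.

Measured compounds:
compound 1 `CC(C)CC1n2cncc2CN(CC2CC2)S1(=O)=O`, 122 nM in an assay on cells for inhibition of cytochrome P450 11B1, mitochondrial (Homo sapiens); a lower number here means a stronger inhibitor, a higher number a weaker inhibitor
compound 2 `C[C@@H](c1ccc(Cl)cc1)N1Cc2cncn2C(CC2(C)COC2)S1(=O)=O`, 340 nM in this assay

Of the two numbers at hand, compound 2 gives the higher one; compound 1 gives the lower one in this assay, and the gap between the two lies beyond the scatter. The two compounds differ in several places at once, so nothing is known about which part of the structure carries that gap.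

Compound 3 `C[C@@H](c1ccc(Cl)cc1)N1Cc2cncn2C(C[C@@H](O)c2ccccc2)S1(=O)=O` is not yet measured. It differs from compound 2 in one place: hydroxy(phenyl)methyl in place of 3-methyloxetan-3-yl on a saturated chain carbon bound to a saturated ring carbon. Within the data shown here, no step between measured compounds tells how a change of this kind plays out on the shared core, since compound 1 and compound 2 differ in more than this one group. The expectation for compound 3 in this assay therefore rests on the value of compound 2 alone, and the step of a 1.2-fold lower number from compound 2 to compound 3 (0.08 log units; within the scatter) is expected to be small, not clearly beyond the scatter, with the direction open. The number for compound 3 is estimated at 280 nM, with a range from 90 nM to 900 nM.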

Compound 3, half-maximal inhibitory concentration: 234 nM
Beside the measured number, compound 3's estimate is 1.2-fold (0.08 log units) above it, within the range that was stated.
By their numbers in this assay, from the lowest: compounds 1, 3 and 2 (each within the scatter of the next, the first and the last beyond it).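

In this assay, among these compounds, hydroxy(phenyl)methyl in place of 3-methyloxetan-3-yl on a saturated chain carbon bound to a saturated ring carbon gives a 1.5-fold lower number from compound 2 to compound 3 (0.16 log units; within the scatter), the first step that can be read at this position. On this shared core, then, the 3-methyloxetan-3-yl group can give way to a larger group carrying a six-membered aromatic ring, a hydrogen-bond donor and a defined stereocentre with no change beyond the scatter, although this rests on a single pair and sets no general tolerance for the position. No measurement at hand bears on why the number holds across this exchange.

The contributions of the hydroxy group and the phenyl ring remain unseparated, and a plain 2-phenylethyl chain would be the direct test of the hydroxy group, while the opposite configuration at the carbinol carbon would test the stereocentre. Going by these compounds, how this position responds to an amine or a carboxylic acid at the end of the chain also remains open, as does whether any group here can move the number beyond the scatter in either direction.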